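The compounds below may be only part of what the source reports. "The series", "measured", "known", "first", "only" and "open" are said of these compounds alone.

Measured compounds:
- compound 1 `Cc1nc(-c2ccc(F)cc2)c(C(=O)N2CCN(c3cccc(Cl)c3)CC2)o1`: 40.1 nM
- compound 2 `Cc1nc(-c2cccc(F)c2)c(C(=O)N2CCN(c3cc(Cl)cc(Cl)c3)CC2)o1`: 41.7 nM
- compound 3 `COc1cccc(N2CCN(C(=O)c3oc(C)nc3-c3ccc(F)cc3)CC2)c1`: 112 nM

In a functional assay on HL-60 cells (Homo sapiens) for inhibition, read by MTT assay, with a stated time of 72 h (on this read-out higher numbers stand for weaker inhibition and lower numbers for stronger inhibition), compound 3 gives the highest number of the three; compound 2 sits nearest, and compound 1 furthest, both beyond the scatter. The next compound in the series is compound 4 `Cc1nc(-c2ccc(F)cc2)c(C(=O)N2CCN(c3cc(Cl)cc(Cl)c3)CC2)o1`, not yet measured.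

The change from compound 3 to compound 4 is 3,5-dichlorophenyl in place of 3-methoxyphenyl on an amine nitrogen in a ring.

Among the measured compounds shown here, one measured step bears on this directly: a 2.8-fold higher number from compound 1 to compound 3 (0.45 log units; beyond the scatter). Running that exchange the other way, chloro in place of methoxy on the same ring carbon, points back toward the level of compound 1. Compound 2 already carries the 3,5-dichlorophenyl group that enters here, though it differs from compound 4 elsewhere on the shared core, and its number stands within the scatter of compound 1. No step is shown from compound 1 or compound 2 to compound 4, so those values are taken only as an indication of where a 3,5-dichlorophenyl-bearing member of the series tends to land.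

The expected step is therefore a fall in this assay, roughly undoing that earlier rise: a 2.8-fold lower number from compound 3 to compound 4 (0.45 log units; beyond the scatter). Compound 4 is estimated at 40 nM, with a range from 20 nM to 85 nM.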

Compound 4, half-maximal inhibitory concentration: 52.1 nM
For compound 4 the middle estimate is 1.3-fold (0.11 log units) below the measured one, within the range that was stated.
By their numbers in this assay, from the lowest: compounds 1, 2 and 4 (each within the scatter of the next); then compound 3.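

In this assay the exchange on the amine nitrogen of the ring, with the 4-fluorophenyl core held fixed, gives a 2.1-fold lower number from compound 3 to compound 4 (0.33 log units; beyond the scatter) and so places 3,5-dichlorophenyl clearly apart from 3-methoxyphenyl. The second chloro adds nothing that can be read, since chloro in place of hydrogen gives a 1.3-fold higher number from compound 1 to compound 4 (0.11 log units; within the scatter) and stays within the scatter, and the fluoro exchange on the other aromatic ring, 4-fluorophenyl in place of 3-fluorophenyl, gives a 1.2-fold higher number from compound 2 to compound 4 (0.10 log units; within the scatter) and also stays within the scatter, so compounds 1, 2 and 4 form one level that tolerates both changes. No measurement at hand accounts for the gap between the chloro-bearing compounds and compound 3.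

Open, on these data alone, is whether that level belongs to chloro itself or would also hold with a trifluoromethyl, a nitrile or a dimethylamino group on the same aromatic ring. Also open, as far as these compounds go, is where the plain phenyl group stands, which would show whether the chloro lowers the number or the methoxy raises it.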